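Isopropylsulfonyl in Place of Isobutoxycarbonyl: an Estimate

A few compounds are considered here, and "the series" means these few. Any claim that something is new, unique, unknown or untested is made for them only; others in the source may bear on it.

Three compounds have been measured:
compound 1, `CC(C)(C)OC(=O)N1CCC(Oc2cccc3c2CCN3c2ccc(S(C)(=O)=O)cc2)CC1`, 92%
compound 2, `CC(C)OC(=O)N1CCC(Oc2cccc3c2CCN3c2ccc(S(C)(=O)=O)cc2F)CC1`, 62%
compound 3, `CC(C)COC(=O)N1CCC(Oc2ncnc3c2CCN3c2ccc(S(C)(=O)=O)cc2F)CC1`, 94%

All three share a core and were tested in a functional assay on CHO-K1 cells with Glucose-dependent insulinotropic receptor (Homo sapiens) as the target, read by a luciferase reporter, with a stated time of 5 h; on this read-out higher numbers stand for larger maximal responses and lower numbers for smaller maximal responses. Compound 1 gives 92%, compound 2 gives 62%, and compound 3 gives 94%. Compound 3 holds the highest of the three numbers; compound 1 lies within the usual scatter of it, while compound 2 sits beyond the scatter below it. Going by the values given here, none of these three pairs differ in a single place, so no measured step isolates any one change.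

Compound 4, `CC(C)S(=O)(=O)N1CCC(Oc2ncnc3c2CCN3c2ccc(S(C)(=O)=O)cc2F)CC1`, has not yet been measured. It differs from compound 3 in one place: isopropylsulfonyl in place of isobutoxycarbonyl on an amine nitrogen in a ring. Among the compounds with values here, no measured pair shows what such a swap on this ring nitrogen does, so the expectation rests only on the spread of the three numbers. The values of compound 1 and compound 3 suggest the shared core can reach a high maximal response, and the value of compound 2 shows that a change in the attached group can bring it down. A small downward step, possibly none beyond the scatter, is expected: a number 14 percentage points lower from compound 3 to compound 4 (beyond the scatter). Compound 4 is therefore estimated at 80%, in a range from 55% to 100%.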

Compound 4, largest response reached (reported as percent of maximum), in percent of the reference or control that the assay uses: 62%
Compound 4: middle estimate off by 18 percentage points, on the high side; low and high end bracket the measured number.
By their numbers in this assay, from the lowest: compounds 2 and 4 (each within the scatter of the next); then compounds 1 and 3 (each within the scatter of the next).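

Going by these compounds alone, this step is the first measurement that isolates the group on this ring nitrogen. In this assay, isopropylsulfonyl in place of isobutoxycarbonyl on an amine nitrogen in a ring gives a number 32 percentage points lower from compound 3 to compound 4 (beyond the scatter), a large change with the rest of the molecule held constant. The largest response of this compound therefore depends on which group sits at this position, even though the leaving and entering groups both have no ring, no net charge and 2 hydrogen-bond acceptors, and no measurement shown here says what lies behind the drop.

The compounds shown leave open whether the drop goes with the sulfonyl link itself or with the isopropyl part attached to it, a question that a butylsulfonyl or phenylsulfonyl group at the same nitrogen could help to answer. They also leave open whether the same swap would lower the response to a similar extent on the core of compound 1, where a single change of this kind would show how far the effect carries over.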